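The compounds below may be only part of what the source reports. "The series", "measured", "known", "first", "only" and "open" are said of these compounds alone.

The series centres on a shared core carrying an amide-bearing aryl group, and the step of interest leads from compound 1 `CCN(CC)c1ccc(N2C(=O)CSC2c2cccc(C(=O)NCCCCc3ccccc3)c2)cc1` to compound 4 `O=C(NCCCCc1ccccc1)c1cccc(C2SCC(=O)N2c2ccc(C3CC3)cc2)c1`, which has not yet been tested. In a functional assay on HOS-TE85 cells (Homo sapiens) for inhibition, read by CCK-8 assay, with a stated time of 72 h (on this read-out higher numbers stand for weaker inhibition and lower numbers for stronger inhibition), compound 1 gives only a limit of the assay, > 1000 nM, and no number. Compound 2 `COc1ccccc1N1C(=O)CSC1c1cccc(C(=O)NCCCCn2cncn2)c1` likewise gives only a limit, > 1000 nM, in this assay. Among the compounds with values here, compound 3 `CC1SC(c2cccc(C(=O)NCCCCc3ccccc3)c2)N(c2cccc(C3CC3)c2)C1=O`, which also carries a cyclopropyl group, gives 295 nM in this assay, and it is the only compound of the three with a measured number. Two of the three values therefore sit at the same boundary (the limit of > 1000 nM in this assay, at which 2 of the 3 values shown sit), so compound 1 stands among the weakest of what has been measured, without a number of its own to place it.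

The change from compound 1 to compound 4 is cyclopropyl in place of diethylamino on an aromatic carbon. Within the data shown here, no step between measured compounds isolates this change, so the size of the step must be guessed. Compound 3, carrying a cyclopropyl group, gives 295 nM in this assay. Compound 1, by contrast, has returned only a limit of the assay and no number. A step toward stronger inhibition is therefore expected, of modest size an at least 1.6-fold lower number from compound 1 to compound 4 (0.22 log units; that floor lies within the scatter). Compound 4 is thus estimated at 600 nM in this assay, within a range from 200 nM to 2000 nM, with a real chance that it again returns only a limit.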

Compound 4, half-maximal inhibitory concentration: 217 nM
For compound 4 the middle estimate is 2.8-fold (0.44 log units) above the measured one; the measured number falls inside the stated range.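

In this assay, within the data shown here, replacing 4-(diethylamino)phenyl with 4-cyclopropylphenyl gives an at least 4.6-fold lower number from compound 1 to compound 4 (0.66 log units; beyond the scatter), the first step that isolates a single change. It shows that the aromatic carbon para to a large group is not indifferent to what it carries: with the rest of the molecule unchanged, cyclopropyl in place of diethylamino turns a result without a number into a measured value. The true size of the step remains unknown, and the printed figure is only a floor, because compound 1 holds a limit of the assay and not a number: the limit of > 1000 nM in this assay, at which 2 of the 4 values shown sit.

The compounds shown cannot separate the loss of the nitrogen of diethylamino from the arrival of the three-membered ring, and neither a smaller amine such as dimethylamino nor an open carbon group such as isopropyl appears at this position to tell the two apart. Among these compounds, whether the same change would carry over to a compound with a different amide chain, such as the one in compound 2, also stays open.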